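A few compounds are considered here, and "the series" means these few. Any claim that something is new, unique, unknown or untested is made for them only; others in the source may bear on it.

Among the measured compounds shown here, in a functional assay on HeLa cells (Homo sapiens) for antiproliferative activity, read by sulforhodamine B assay (on this read-out lower numbers stand for stronger inhibition of growth and higher numbers for weaker inhibition of growth), compound 2 `OC[C@@H]1O[C@H](COCc2ccccc2)[C@@H](OCc2ccccc2)[C@H](OCc2ccccc2)[C@H]1O` gives 25800 nM, the only actual number so far. Compound 1 `CC(C)C[C@@H]1O[C@H](COCc2ccccc2)[C@@H](OCc2ccccc2)[C@H](OCc2ccccc2)[C@H]1O` gives > 50000 nM, which is a limit of the assay. Compound 3 `O[C@@H]1[C@@H](OCc2ccccc2)[C@H](OCc2ccccc2)[C@@H](COCc2ccccc2)O[C@H]1CC1CCCCC1` has cyclohexyl in place of hydroxy on a saturated chain carbon bound to a saturated ring carbon. For the measured compounds named here, the one measured step bearing on this change, with hydroxy in place of isopropyl at the same place, is an at least 1.9-fold lower number from compound 1 to compound 2 (0.28 log units; that floor lies within the scatter). On that step alone, a slightly higher number, hardly beyond the scatter, is expected in this assay. The expected step is a 1.7-fold higher number from compound 2 to compound 3 (0.24 log units; within the scatter). Compound 3 is estimated at 45000 nM, with an expected range from 18000 nM to 90000 nM.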

Compound 3, concentration for 50% growth inhibition: 9500 nM
The estimate for compound 3 lay 4.7-fold (0.68 log units) above the measured number; measured number below the stated range.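

In this assay, a carbon group at this place does not have to weaken growth inhibition: cyclohexyl in place of hydroxy gives a 2.7-fold lower number from compound 2 to compound 3 (0.43 log units; beyond the scatter). Cyclohexyl also improves on isopropyl at the same place, with an at least 5.2-fold lower number from compound 1 to compound 3 (0.72 log units; beyond the scatter). That step is only a floor, as one end of it is a limit: the limit of > 50000 nM in this assay, at which 1 of the 3 values shown sits.

As far as these compounds go, whether the gain needs a ring at all stays open, since only isopropyl and cyclohexyl are compared here. From the compounds shown here alone, how a phenyl ring, a longer straight chain or an amine would read at this place is also open.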